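The source may hold more compounds than are shown below. What is called first, only, known or untested is meant among the compounds shown, and "the series" means these compounds.

Measured compounds:
Compound 1 `CC(C)=CC[C@@H](OC[C@@H](C)O)C1=CC(=O)c2c(O)ccc(O)c2C1=O` gives 22500 nM
Compound 2 `CCCC(CC(=O)O[C@H](CC=C(C)C)C1=CC(=O)c2c(O)ccc(O)c2C1=O)OC(C)=O` gives 51200 nM

In a functional assay on HeLa cells (Homo sapiens) for cytotoxicity, read by MTT assay (on this read-out lower numbers stand for stronger inhibition and higher numbers for weaker inhibition), compound 2 stands at the higher of the two numbers, and compound 1 stands lower by a gap beyond the usual scatter. Compound 3 `CC[C@@](C)(O)CC(=O)O[C@H](CC=C(C)C)C1=CC(=O)c2c(O)ccc(O)c2C1=O` has not yet been measured; it differs from compound 2 in one place: 1-hydroxy-1-methylpropyl in place of 1-acetoxybutyl on a saturated chain carbon bound to a carbonyl carbon. Going by the values given here, no step of this kind has been measured here, so the expectation rests only on these two values. The step from compound 2 to compound 3 is estimated as a small move to a lower number, within the scatter: a 1.6-fold lower number from compound 2 to compound 3 (0.20 log units; within the scatter). Compound 3 is expected to give 32000 nM, with a range from 13000 nM to 80000 nM.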

Compound 3, half-maximal inhibitory concentration: 17900 nM
The estimate for compound 3 lay 1.8-fold (0.25 log units) above the measured number; the range from low to high includes it.
By their numbers in this assay, from the lowest: compounds 3 and 1 (each within the scatter of the next); then compound 2.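

In this assay, 1-hydroxy-1-methylpropyl in place of 1-acetoxybutyl on a saturated chain carbon bound to a carbonyl carbon gives a 2.9-fold lower number from compound 2 to compound 3 (0.46 log units; beyond the scatter) and so shows that the number responds to the group at this position. Compound 1, which carries 2-hydroxypropyl on an oxygen on a saturated carbon, cannot be told apart from compound 3, which has (2-hydroxy-2-methylbutyl)carbonyl there: the step reads a 1.3-fold lower number from compound 1 to compound 3 (0.10 log units; within the scatter) and stays within the scatter. As far as these compounds go, how an amine or a carboxylic acid at the first position would read remains open. No measurement at hand explains these steps.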